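The compounds below may be only part of what the source reports. "The series", "measured", "known", "first", "only" and "open" are said of these compounds alone.

Compound 1 `CCCCn1nc2oc(=O)cc(C)c2c1C` gives only a limit of the assay, > 100 mg/kg, in a functional assay on the whole organism with Mus musculus as the target, in the writhing test; a lower number here means that less compound is needed, a higher number that more compound is needed for the effect.
Compound 2 `CCN(CC)CCn1nc2oc(=O)cc(C)c2c1C` gives 100 mg/kg in this assay.

For the measured compounds named here, compound 2 thus stands as the only compound with an actual number in this assay; the one other value shown is a limit rather than a number. Going by the values given here, the single measured step, a number no higher from compound 1 to compound 2 (the limit leaves the size open), cannot be read for its size because of the limit (the limit of > 100 mg/kg in this assay, at which 1 of the 2 values shown sits), so it tells only that compound 2 needs no more compound than compound 1.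

Compound 3 `Cc1cc(=O)oc2nn(CCO)c(C)c12` differs from compound 2 at the same place that step touched: hydroxy in place of diethylamino on a saturated chain carbon, two bonds along the chain from an aromatic nitrogen. Among the compounds with values here, the only step that bears on this change is the one from compound 1 to compound 2, and its size stays open. Within the data shown here, no measured step here shows what hydroxy does at this position, so no direction beyond the usual scatter can be expected with confidence.

Compound 3 is therefore estimated at 100 mg/kg in this assay, within a range of 40 mg/kg to 250 mg/kg, which means an expected step of no change at the digits printed from compound 2 to compound 3 (within the scatter).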

Compound 3, dose for half-maximal effect: > 100 mg/kg
Compound 3: only a limit was reported; the forecaster's own chance of this, stated with the estimate: 40%; the middle value lies on the limit itself.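

Putting hydroxy in place of diethylamino on this saturated chain carbon gives a number no lower from compound 2 to compound 3 (the limit leaves the size open), so in this assay hydroxy does not bring the required dose below that of compound 2. For the compounds shown here, compound 2 therefore remains the only compound here with an actual number, while compound 3 joins compound 1 in giving only a limit. The size of each new step cannot be read, and the step between compound 1 and compound 3 does not even show a direction: the limit of > 100 mg/kg in this assay, at which 2 of the 3 values shown sit.

How far compound 1 and compound 3 lie past their limits remains open, so the compounds shown cannot rank hydroxy against the original chain end or measure how much diethylamino differs from either one. Going by these compounds alone, it also remains open whether another group at this place, such as a cyclic amine like morpholine or a carboxylic acid, or a longer chain carrying the diethylamino group, would give an actual number in this assay and how that number would compare with the one for compound 2.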